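The compounds below may be only part of what the source reports. "The series", "measured", "known", "first", "only" and "open" are said of these compounds alone.

Compound 2 `Cc1cc(-c2cnc(NCc3c(F)ccc4c3CCO4)c3cn[nH]c(=O)c23)n(C)n1` gives 3 in a physicochemical assay for lipophilicity, using the shake flask method, in phosphate buffer, measured as octanol-water partition, with a stated time of 30 min, at pH 7.4; a lower number here means a more polar compound, a higher number a more lipophilic compound. Among the three compounds measured it stands second highest: compound 1 `Cc1nccn1-c1cnc(NCc2c(F)ccc3c2CCO3)c2cn[nH]c(=O)c12` gives 2.1, and compound 3 `O=C(Nc1ccccc1)c1cnc(NCc2c(F)ccc3c2CCO3)n2cnnc12` gives 4.1. Within the data shown here, the only single-point step recorded runs a number 0.90 log units higher from compound 1 to compound 2 (beyond the scatter), with 1,3-dimethyl-1H-pyrazol-5-yl in place of 2-methyl-1H-imidazol-1-yl on an aromatic carbon. Compound 4 `O=C1CCCN1c1cnc(NCc2c(F)ccc3c2CCO3)c2cn[nH]c(=O)c12` differs from compound 2 in one place: 2-oxopyrrolidin-1-yl in place of 1,3-dimethyl-1H-pyrazol-5-yl on an aromatic carbon. Among the measured compounds shown here, no measured step exchanges an aromatic five-membered ring for a non-aromatic one at this position, so the step from compound 1 to compound 2 bears on it only as a guide to the size that a change of this ring can produce in this assay. The group that now leaves is the same one whose arrival raised the number in that step. Compound 4 is therefore expected to show a step of a number 1.30 log units lower from compound 2 to compound 4 (beyond the scatter) in this assay, a drop beyond the scatter. In this assay compound 4 is estimated at 1.7, between 1.2 and 2.3.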

Compound 4, distribution coefficient: 1.8
Beside the measured number, compound 4's estimate is 0.10 log units below it; the range from low to high includes it.
By their numbers in this assay, from the lowest: compounds 4 and 1 (each within the scatter of the next); then compound 2; then compound 3.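

In this assay, this aromatic carbon has now carried a non-aromatic ring as well as aromatic ones, and exchanging 1,3-dimethyl-1H-pyrazol-5-yl for 2-oxopyrrolidin-1-yl gives a step of a number 1.20 log units lower from compound 2 to compound 4 (beyond the scatter). The same entering group in place of 2-methyl-1H-imidazol-1-yl gives a number 0.30 log units lower from compound 1 to compound 4 (within the scatter), so an aromatic ring at this position does not by itself set the number: compound 1, with an aromatic ring, and compound 4, with a non-aromatic one, cannot be told apart, while compound 2 stands apart from both. Nothing available accounts for these differences.

As far as these compounds go, what an amine or a carboxylic acid at this position would give remains open. Also open, from the compounds shown here alone, is how much of the step from the pyrazole depends on its two methyl groups, and whether the same exchange would behave alike on the core of compound 3.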